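A few compounds are considered here, and "the series" means these few. Any claim that something is new, unique, unknown or untested is made for them only; others in the source may bear on it.

Of the compounds shown here, three have been measured in an assay on HEK293 cells for positive allosteric modulation of metabotropic glutamate receptor 2 (Rattus norvegicus), read by thallium flux, with a stated time of 2.5 min; a lower number here means a smaller maximal response, a higher number a larger maximal response. Compound 1 `Cc1c(OCCCCOc2ccc(C(=O)O)cc2)ccc(C(=O)CC2CCCC2)c1O` gives 82.6%, and compound 2 `Cc1c(OCCCCOc2cccc(C(=O)O)c2)ccc(C(=O)CC(C)C)c1O` gives 84.5%. Compound 3 `COC(=O)c1ccc(OCCCCOc2ccc(C(=O)CC3CCCC3)c(O)c2C)cc1` gives 12.2%, the lowest of the three numbers, and both other compounds stand beyond the scatter above it. Among the compounds with values here, the one measured step that reaches compound 3, a number 70.4 percentage points lower from compound 1 to compound 3 (beyond the scatter), shows how much is lost when the free acid is capped as a methyl ester.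

Compound 4 `Cc1c(OCCCCOc2cccc(C(=O)O)c2)ccc(C(=O)CC2CCCC2)c1O` has not been measured. It differs from compound 3 in one place: 3-carboxyphenyl in place of 4-(methoxycarbonyl)phenyl on an oxygen on a saturated carbon. This change undoes the ester and brings back a carboxylic acid, now as 3-carboxyphenyl, the same group carried by compound 2, which gives 84.5% in this assay. The step from compound 1 to compound 3 is the only one that bears directly, and it was large and downward; reversing it should be large and upward, and compound 2 suggests the new position of the acid makes little difference. Compound 4 is therefore expected to give about 83%, between 68% and 95%, an expected rise of a number 70.8 percentage points higher from compound 3 to compound 4 (beyond the scatter).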

Compound 4, largest response reached (reported as percent of maximum), in percent of the reference or control that the assay uses: 80.6%
Compound 4: middle estimate off by 2.4 percentage points, on the high side; measured number inside the range.
By their numbers in this assay, from the lowest: compound 3; then compounds 4, 1 and 2 (each within the scatter of the next).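

In this assay, 3-carboxyphenyl in place of 4-(methoxycarbonyl)phenyl gives a number 68.4 percentage points higher from compound 3 to compound 4 (beyond the scatter) in a single step, so a free carboxylic acid on this ring goes with a large response in the cyclopentyl compounds whichever of these two ring positions carries it. Two further comparisons separate nothing: 3-carboxyphenyl in place of 4-carboxyphenyl gives a number 2 percentage points lower from compound 1 to compound 4 (within the scatter) and cyclopentyl in place of isopropyl gives a number 3.9 percentage points lower from compound 2 to compound 4 (within the scatter) in the same assay, so the compounds with a free acid cannot be told apart here. Nothing available explains why the ester and the acid differ so much.

Still open, going by these compounds, is whether 2-carboxyphenyl would match these acids, and whether 3-(methoxycarbonyl)phenyl would lose as much as the 4-substituted ester did. A tetrazole or an amide in place of the carboxylic acid, or a longer chain linking the two ring oxygens, also remains untested by the compounds shown.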